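Cytotoxicity of the shared core: amide versus triazole ethers

The compounds below may be only part of what the source reports. "The series", "measured", "known", "first", "only" and "open" are said of these compounds alone.

Measured so far:
- compound 1 `COc1ccc(C[C@H]2COC(=O)[C@@H]2Cc2ccc(OCC(=O)Nc3ccccc3)c(OC)c2)cc1OC`: in an ADME assay on HeLa cells (Homo sapiens) for cytotoxicity, read by MTT assay (on this read-out higher numbers stand for weaker inhibition and lower numbers for stronger inhibition), compound 1 reaches only a limit, >= 600000 nM.
- compound 2 `COc1ccc(C[C@H]2COC(=O)[C@@H]2Cc2ccc(OCC(=O)N3CCCCC3)c(OC)c2)cc1OC`: in this assay compound 2 gives 293000 nM.
- compound 3 `COc1ccc(C[C@H]2COC(=O)[C@@H]2Cc2ccc(OCc3cn(-c4ccc(Br)cc4)nn3)c(OC)c2)cc1OC`: in this assay compound 3 gives 128000 nM.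

Compound 3 stands at the lowest of the two numbers; the nearest is compound 2, with a 2.3-fold lower number from compound 2 to compound 3 (0.36 log units; beyond the scatter). Compound 1 is known only as a limit, (the limit of >= 600000 nM in this assay, at which 1 of the 3 values shown sits).

The step now followed is from compound 3 to compound 4 `COc1ccc(C[C@H]2COC(=O)[C@@H]2Cc2ccc(OCC(=O)N3CCCC3)c(OC)c2)cc1OC`, changing ((pyrrolidin-1-yl)carbonyl in place of 1-(4-bromophenyl)-1H-1,2,3-triazol-4-yl on a saturated chain carbon bound to an oxygen on an aromatic ring). The step that bears on it is a 2.3-fold lower number from compound 2 to compound 3 (0.36 log units; beyond the scatter), where the (piperidin-1-yl)carbonyl gave the higher number; compound 4 carries a close relative of that group, so the reverse direction is expected, a modest rise in the number. The step of an at least 2.0-fold lower number from compound 1 to compound 2 (0.31 log units; beyond the scatter) shows the two amide ethers differ at most modestly. Compound 4 is therefore expected near compound 2, with a 2.2-fold higher number from compound 3 to compound 4 (0.34 log units; beyond the scatter), estimated at 280000 nM, range 130000 nM to 600000 nM.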

Compound 4, half-maximal inhibitory concentration: >= 600000 nM
Compound 4: only a limit was reported (the forecaster's own chance of this, stated with the estimate: 15%); middle value at least 2.1-fold (0.33 log units) from the limit.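

In this assay, the amide ring is not a neutral choice at this position: pyrrolidin-1-yl in place of piperidin-1-yl on a carbonyl carbon gives an at least 2.0-fold higher number from compound 2 to compound 4 (0.31 log units; beyond the scatter). Replacing the 1-(4-bromophenyl)-1H-1,2,3-triazol-4-yl with (pyrrolidin-1-yl)carbonyl gives an at least 4.6-fold higher number from compound 3 to compound 4 (0.67 log units; beyond the scatter), so compound 3 keeps the lowest number of the four. Compound 4 is known only as a limit, as is compound 1, and the step between them cannot be read: the limit of >= 600000 nM in this assay, at which 2 of the 4 values shown sit.

Going by these compounds, it remains open whether the lower number of compound 3 goes with the triazole itself or with its bromine, a question a plain 1-phenyl-1H-1,2,3-triazol-4-yl would address. On these data alone, how a (morpholin-4-yl)carbonyl or a longer chain before the amide carbonyl would read here is also open.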